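Octyl to isopropyl on the nitrogen

A few compounds are considered here, and "the series" means these few. Any claim that something is new, unique, unknown or untested is made for them only; others in the source may bear on it.

In a functional assay on A549 cells (Homo sapiens) for antiproliferative activity, read by MTT assay, with a stated time of 48 h (on this read-out lower numbers stand for stronger inhibition of growth and higher numbers for weaker inhibition of growth), compound 1 `CCCCCCCCN(Cc1ccc(C(=O)NO)cc1)c1ncc(-c2ccc(C)cc2)s1` gives 4630 nM and compound 2 `CCCCN(Cc1ccc(C(=O)NO)cc1)c1ncc(-c2ccc(C)cc2)s1` gives 4780 nM. These two values lie within the scatter of each other, so compound 1 stands level with compound 2 and neither ranks ahead of the other.

The next compound to be read is compound 3 `Cc1ccc(-c2cnc(N(Cc3ccc(C(=O)NO)cc3)C(C)C)s2)cc1`, which keeps the core of compound 1 and carries one change: isopropyl in place of octyl on a nitrogen on an aromatic ring. In words, this is isopropyl in place of octyl on a nitrogen on an aromatic ring.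

Among the measured compounds shown here, only one measured step bears on it, a change in the same chain, and that step is a 1.0-fold higher number from compound 1 to compound 2 (0.01 log units; within the scatter). For the measured compounds named here, no measured compound carries isopropyl, so the group itself is untested and a single step gives thin support. On the evidence of compound 2, with its step of a 1.0-fold higher number from compound 1 to compound 2 (0.01 log units; within the scatter), no shift beyond the scatter is expected in this assay, in either direction.

The expected step is a 1.1-fold higher number from compound 1 to compound 3 (0.03 log units; within the scatter). For compound 3 the estimated value is 5000 nM, with an expected range of 2400 nM to 10000 nM.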

Compound 3, concentration for 50% growth inhibition: 3830 nM
For compound 3 the middle estimate is 1.3-fold (0.12 log units) above the measured one, and the stated range covers the measured number.
By their numbers in this assay, from the lowest: compounds 3, 1 and 2 (each within the scatter of the next).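

In this assay the group on this nitrogen now runs from octyl through butyl to isopropyl, and the change to isopropyl gives a 1.2-fold lower number from compound 1 to compound 3 (0.08 log units; within the scatter) and also a 1.2-fold lower number from compound 2 to compound 3 (0.10 log units; within the scatter) in the same read-out. The level reading of compounds 1 and 2 therefore extends to a group of 3 carbon in place of 8 carbon, and to a group other than an unbranched chain, so no dependence on the size or shape of this group can be read from compounds 1, 2 and 3. Nothing available gives a reason why these three compounds stand level.

From the compounds shown here alone, all three groups are plain saturated carbon groups, so it stays open whether this position remains as flat when it carries a group of another kind, such as a terminal amine or carboxylic acid on the chain, or a cyclohexyl or benzyl group. The compounds shown also leave open how a bare hydrogen on this nitrogen would compare with compounds 1, 2 and 3, and whether any change here can move the number beyond the scatter.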